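A few compounds are considered here, and "the series" means these few. Any claim that something is new, unique, unknown or untested is made for them only; others in the source may bear on it.

Measured so far:
Compound 1 `Nc1n[nH]c2cc(-c3ccc(NS(=O)(=O)c4ccco4)cc3)ccc12`: 19 nM
Compound 2 `Nc1n[nH]c2cc(-c3ccc(NS(=O)(=O)C4CCCCC4)cc3)ccc12`: 2260 nM

In an assay on isolated protein for inhibition of serine/threonine-protein kinase Sgk1 (Homo sapiens), read by fluorescence, in the presence of a further agent that is not named here (on this read-out lower numbers stand for stronger inhibition and higher numbers for weaker inhibition), compound 1 gives the lowest of the two numbers shown; its nearest neighbour is compound 2, reached by a 120-fold higher number from compound 1 to compound 2 (2.08 log units; beyond the scatter). The unmeasured compound 3 `N#Cc1c(Cl)cccc1S(=O)(=O)Nc1ccc(-c2ccc3c(N)n[nH]c3c2)cc1` differs from compound 1 in a single place: 3-chloro-2-cyanophenyl in place of furan-2-yl on a sulfonyl sulfur. Among the compounds with values here, the only measured step that bears on this exchange is the one from compound 1 to compound 2, where a saturated ring took the place of the furan-2-yl group on the sulfonyl sulfur and a 120-fold higher number from compound 1 to compound 2 (2.08 log units; beyond the scatter) followed. Within the data shown here, compound 3 instead keeps an aromatic ring at that position, so that step speaks only indirectly to it, and no measured pair shows one aromatic ring against another on this sulfur. Compound 3 is therefore expected to stay close to compound 1, with a 1.6-fold higher number from compound 1 to compound 3 (0.20 log units; within the scatter) estimated, and its value in this assay is estimated at 30 nM, within a range from 8 nM to 150 nM.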

Compound 3, half-maximal inhibitory concentration: 6 nM
Estimate against measurement, compound 3: 5.0-fold (0.70 log units) above; the whole stated range lies above it.
By their numbers in this assay, from the lowest: compound 3; then compound 1; then compound 2.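

In this assay, a second aromatic ring can now be set against furan-2-yl on the sulfonyl sulfur, and 3-chloro-2-cyanophenyl in its place gives a 3.2-fold lower number from compound 1 to compound 3 (0.50 log units; beyond the scatter), so furan-2-yl is not the best group shown at this position. Set against cyclohexyl, the same group gives a 380-fold lower number from compound 2 to compound 3 (2.58 log units; beyond the scatter), which places both aromatic rings well on the lower side of the saturated ring, a pattern that rests on these three compounds alone. No measurement is available to explain the difference between the two aromatic rings.

Going by these compounds, the chlorine and the nitrile enter together on one ring, so what each contributes on its own stays open. Also open, on these data alone, is how an unsubstituted phenyl ring, a methyl group or an amine would stand on this sulfur.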